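Compound 2 to compound 3: a ring leaves

This account rests on a few compounds, and the source may have more. Where it says the series, first, only, none or still open, it means among the compounds named here.

Measured in an in vitro ADME assay on microsomes (Homo sapiens) for metabolic stability; on this read-out lower numbers stand for a shorter-lived compound and higher numbers for a longer-lived compound:
- Compound 1 `O=C(Nc1ccncc1)Nc1ccc(-c2nc(N3CC4CCC(C3)O4)c3cnn(C4CCC5(CC4)OCCO5)c3n2)cc1`: 0.217 h
- Compound 2 `CNC(=O)Nc1ccc(-c2nc(N3CC4CCC(C3)O4)c3cnn(C4CCC5(CC4)OCCCO5)c3n2)cc1`: > 0.5 h

Only compound 1 has an exact number, 0.217 h, in this assay. Compound 2 stands at > 0.5 h, which is a limit of the assay and not a number.

Compound 3 `CNC(=O)Nc1ccc(-c2nc(N3CC4CCC(C3)O4)c3cnn(C4CCC(OC)(OC)CC4)c3n2)cc1` differs from compound 2 in one place, on an aromatic nitrogen of a five-membered aromatic ring with 2 nitrogen: a group of 10 heavy atoms (8 carbon, 2 oxygen; one six-membered non-aromatic ring of carbon only) in place of a group of 11 heavy atoms (9 carbon, 2 oxygen; one six-membered non-aromatic ring of carbon only, one six-membered non-aromatic ring with 2 hetero atoms), on an aromatic nitrogen. The six-membered non-aromatic ring with 2 hetero atoms is gone, while the six-membered non-aromatic ring of carbon only remains.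

Among the compounds with values here, no measured pair isolates this change, so the expectation is a tentative one. Its starting point is the limit of compound 2, > 0.5 h. A modest shortening of the half-life is expected, estimated as an at least 1.1-fold lower number from compound 2 to compound 3 (0.04 log units; that floor lies within the scatter), and a step no larger than the scatter would be no surprise. For compound 3 the expected value in this assay is 0.45 h, within an estimated range of 0.2 h to 1 h.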

Compound 3, half-life: 0.5 h
For compound 3 the middle estimate is 1.1-fold (0.05 log units) below the measured one, and the stated range covers the measured number.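

Compound 3 gives 0.5 h in this assay, which supplies an exact number for a compound in which the six-membered non-aromatic ring with 2 hetero atoms has gone from the group on the aromatic nitrogen, while the six-membered non-aromatic ring of carbon only remains. Removing that ring gives a number no higher from compound 2 to compound 3 (the limit leaves the size open), so this change at this position brings no gain in half-life that the values can show. How much half-life the change costs, if it costs any, cannot be read, because the value of compound 2 is a limit of the assay and not a number: the limit of > 0.5 h in this assay, at which 1 of the 3 values shown sits.

Compound 1 differs from compound 2 in more than one place, so the compounds shown do not tell whether the same change would behave alike with the other urea substituent of compound 1. They also leave open how the half-life would respond if the group on the aromatic nitrogen carried a hydroxyl, an amine or a fluorine on the ring of carbon only.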